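This account rests on a few compounds, and the source may have more. Where it says the series, first, only, none or still open, it means among the compounds named here.

Of the compounds shown here, three sharing one core have been tested in a functional assay, with a stated time of 6 min; on this read-out lower numbers stand for stronger inhibition and higher numbers for weaker inhibition. Compound 1 `CCCCCCCCCCCCCCCCNCn1nc(-c2ccc3c(c2)OCCO3)oc1=S` gives 22900 nM, compound 3 `FC(F)(F)c1ccccc1NCn1nc(-c2ccc3c(c2)OCCO3)oc1=S` gives 9220 nM, and compound 2 `Fc1cccc(NCn2nc(-c3ccc4c(c3)OCCO4)oc2=S)c1` gives 6620 nM. The numbers for compound 2 and compound 3 lie within the scatter of each other, while compound 2 has a lower number than compound 1 by more than the scatter. Compound 4 `S=c1oc(-c2ccc3c(c2)OCCO3)nn1CNc1cccc(Cl)c1` differs from compound 2 in one place: chloro in place of fluoro on an aromatic carbon, which is chloro in place of fluoro on an aromatic carbon. Going by the values given here, no tested pair shows this swap, so no change beyond the scatter is expected in this assay. The expected step is a 1.1-fold lower number from compound 2 to compound 4 (0.04 log units; within the scatter). Compound 4 is estimated at 6000 nM, within an estimated range of 3000 nM to 12000 nM.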

Compound 4, half-maximal inhibitory concentration: 6220 nM
Beside the measured number, compound 4's estimate is 1.0-fold (0.02 log units) below it, within the range that was stated.
By their numbers in this assay, from the lowest: compounds 4, 2 and 3 (each within the scatter of the next); then compound 1.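

In this assay chloro in place of fluoro on this aromatic carbon gives a 1.1-fold lower number from compound 2 to compound 4 (0.03 log units; within the scatter) and so shows that the two halogens cannot be told apart here. This is the first pair shown that differs in one place, which gives the first direct reading of a single change on this ring. No measured evidence explains this result. Still open, on these data alone, is whether a larger or differently charged group at this position, such as methoxy, an amine or a carboxylic acid, would move the number beyond the scatter.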